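A few compounds are considered here, and "the series" means these few. Any claim that something is new, unique, unknown or untested is made for them only; others in the source may bear on it.

Compound 1 `O=C(NCCCOc1ccc2nc(O)ccc2c1)N(C1CC1)[C@@H]1CCC[C@H]1O` gives 67% in a functional assay on the whole organism for inhibition, with Mus musculus as the target, at a dose of 30 mg/kg by the oral route (a higher number here means more inhibition at the dose given (going by the name of the read-out), a lower number less inhibition), the second highest of the three numbers recorded. Compound 2 `O=C(NCCCOc1ccc2nc(O)ccc2c1)N(C1CCCCCCC1)[C@H]1CCCC[C@@H]1O` reaches 100% in this assay, beyond the scatter above compound 1, while compound 3 `CCCCO[C@H]1CCCC[C@@H]1N(C(=O)NCCCOc1ccc2nc(O)ccc2c1)C1CC1` gives 33%, beyond the scatter below it. Compound 4 `O=C(NCCCOc1ccc2nc(O)ccc2c1)N(C1CC1)[C@H]1CCCC[C@@H]1O` carries 2-hydroxycyclohexyl in place of 2-hydroxycyclopentyl on an amide-type nitrogen. Within the data shown here, only one measured step touches this change: a number 34 percentage points lower from compound 1 to compound 3 (beyond the scatter), yet that step alters the ring size and the hydroxyl together, so the ring expansion alone is not isolated; compound 2, which also bears 2-hydroxycyclohexyl, sits at the top of the set. Compound 4 is therefore expected to hold or modestly gain on compound 1, a step of a number 8 percentage points higher from compound 1 to compound 4 (within the scatter), with an estimated 75% between 50% and 95%.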

Compound 4, a percentage reported as inhibition, in the whole organism at one dose (the size of the read-out at that dose, not a potency): 100%
For compound 4 the middle estimate is 25 percentage points below the measured one; the whole stated range lies below it.
By their numbers in this assay, from the lowest: compound 3; then compound 1; then compounds 2 and 4 (each within the scatter of the next).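

In this assay, among these compounds, the change from 2-hydroxycyclopentyl to 2-hydroxycyclohexyl on the amide-type nitrogen, with the hydroxyl kept, is by itself a large step (a number 33 percentage points higher from compound 1 to compound 4 (beyond the scatter)), which the earlier compounds could not separate from the butyl group. With 2-hydroxycyclohexyl held, hydrogen in place of butyl on the oxygen also gives a large step (a number 67 percentage points higher from compound 3 to compound 4 (beyond the scatter)), whereas cyclopropyl in place of cyclooctyl gives none (no change at the digits printed from compound 2 to compound 4 (within the scatter)). No measurement here accounts for these steps. The compounds shown leave open whether an amine in place of the hydroxyl on the cyclohexyl ring, or a methyl on that oxygen, would hold the number.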